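A few compounds are considered here, and "the series" means these few. Any claim that something is new, unique, unknown or untested is made for them only; others in the source may bear on it.

Measured so far in an ADME assay on microsomes from liver (Rattus norvegicus) for metabolic stability, tested at 2.5 uM; a higher number here means faster removal of the compound, a lower number slower removal:
compound 1 `O=S(=O)(c1ccc(F)c(Cl)c1)c1cnc2cc(F)ccc2c1-c1ccc(Cl)cc1` gives 0.45 mL/min
compound 2 `O=S(=O)(c1cc(Cl)cc(Cl)c1)c1cnc2cc(F)ccc2c1-c1ccc(Cl)cc1` gives 0.77 mL/min
compound 3 `O=S(=O)(c1ccc(F)c(F)c1)c1cnc2cc(F)ccc2c1-c1ccc(Cl)cc1` gives 1.41 mL/min

Compound 1 stands lowest of the three numbers in this assay. Its nearest neighbour is compound 2, a 1.7-fold higher number from compound 1 to compound 2 (0.23 log units; within the scatter), a gap that stays within the scatter. Its furthest is compound 3, a 3.1-fold higher number from compound 1 to compound 3 (0.50 log units; beyond the scatter), a modest step beyond the scatter. Between the other two, a 1.8-fold higher number from compound 2 to compound 3 (0.26 log units; within the scatter), again within the scatter.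

Compound 4 `O=S(=O)(c1ccc(F)c(Cl)c1)c1cnc2cc(F)ccc2c1-c1ccc(F)cc1` is not yet measured. It differs from compound 1 in one place: fluoro in place of chloro on an aromatic carbon The change sits on the ring attached to the shared core, para to a large group.

Among the measured compounds shown here, only one measured step is of the same kind, fluoro in place of chloro on an aromatic carbon: from compound 1 to compound 3, on the ring at the sulfonyl sulfur, a 3.1-fold higher number from compound 1 to compound 3 (0.50 log units; beyond the scatter). For the measured compounds named here, no measured step touches the ring where compound 4 changes. Taking that step as the nearest guide, a modest rise is expected in this assay, a 2.0-fold higher number from compound 1 to compound 4 (0.30 log units; within the scatter), though a result within the scatter would not surprise. Compound 4 is therefore estimated at 0.9 mL/min, with a range of 0.45 mL/min to 1.8 mL/min.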

Compound 4, intrinsic clearance in a liver preparation (reported as CLH), per the amount of preparation that the assay uses: 0.89 mL/min
Compound 4: the middle estimate sits 1.0-fold (0.00 log units) above what was measured; low and high end bracket the measured number.
By their numbers in this assay, from the lowest: compounds 1, 2, 4 and 3 (each within the scatter of the next, the first and the last beyond it).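

Among the compounds shown here, this is the first reading at the 4-chlorophenyl ring, on an aromatic carbon para to a large group. In this assay, 4-fluorophenyl in place of 4-chlorophenyl gives a 2.0-fold higher number from compound 1 to compound 4 (0.30 log units; within the scatter) and so does not separate the two halogens here, whereas the same kind of replacement on the ring at the sulfonyl sulfur gives a 3.1-fold higher number from compound 1 to compound 3 (0.50 log units; beyond the scatter) and does. No evidence at hand explains either reading.

The compounds shown leave open how this position responds to groups other than these halogens, such as methoxy, a nitrile or an amine. They also leave open whether 4-fluorophenyl reads the same when the sulfonyl sulfur carries 3,5-dichlorophenyl or 3,4-difluorophenyl instead of the 3-chloro-4-fluorophenyl of compound 4.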